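Removing the aromatic ring from compound 3

The source may report more compounds than this note shows. Statements on the series, on what has been measured and on what is new or still open speak of the compounds shown alone.

In a functional assay on SK-BR-3 cells (Homo sapiens) for antiproliferative activity (on this read-out higher numbers stand for weaker inhibition and lower numbers for stronger inhibition), compound 1 `CC(C)=CCc1cc(C(=O)Nc2cc3ccc(OCCC4CCCCN4)c(C)c3oc2=O)ccc1O` gives 640 nM and compound 2 `CC(C)=CCc1cc(C(=O)Nc2cc3ccc(OCCCN(C)C4CCCCC4)c(C)c3oc2=O)ccc1O` gives 970 nM. These two sit close together: a 1.5-fold higher number from compound 1 to compound 2 (0.18 log units; within the scatter). Compound 3 `CC(C)=CCc1cc(C(=O)Nc2cc3ccc(OCCCN(C)Cc4ccccc4)c(C)c3oc2=O)ccc1O` is the weakest of the three at 10700 nM, the highest number. The gaps to it are large: a 17-fold higher number from compound 1 to compound 3 (1.22 log units; beyond the scatter), and an 11-fold higher number from compound 2 to compound 3 (1.04 log units; beyond the scatter), where benzyl replaces cyclohexyl on an amine nitrogen.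

Compound 4 `CC(C)=CCc1cc(C(=O)Nc2cc3ccc(OCCCN[C@@H]4C[C@H]5CC[C@@H]4C5)c(C)c3oc2=O)ccc1O` brings this change: a group of 8 heavy atoms (7 carbon, 1 nitrogen; 2 five-membered non-aromatic rings of carbon only) in place of a group of 9 heavy atoms (8 carbon, 1 nitrogen; one six-membered aromatic ring of carbon only), on a saturated chain carbon, three bonds along the chain from an oxygen on an aromatic ring. Like compounds 1 and 2, it carries only non-aromatic rings there, though three compounds are a thin basis. A large drop in the number is therefore expected in this assay, roughly reversing the step from cyclohexyl to benzyl. The expected shift is an 8.9-fold lower number from compound 3 to compound 4 (0.95 log units; beyond the scatter). For compound 4 the estimated value is 1200 nM, within a range of 400 nM to 4000 nM.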

Compound 4, half-maximal inhibitory concentration: 770 nM
For compound 4 the middle estimate is 1.6-fold (0.19 log units) above the measured one; the range from low to high includes it.
By their numbers in this assay, from the lowest: compounds 1, 4 and 2 (each within the scatter of the next); then compound 3.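

Swapping the benzyl(methyl)amino group for the two-ring group gives a 14-fold lower number from compound 3 to compound 4 (1.14 log units; beyond the scatter) in this assay and restores the level of the other compounds, though the entering group also brings a hydrogen-bond donor, so more than the aromatic ring changes. The comparisons a 1.3-fold lower number from compound 2 to compound 4 (0.10 log units; within the scatter) and a 1.2-fold higher number from compound 1 to compound 4 (0.08 log units; within the scatter) show that this position accepts quite different non-aromatic groups, with compound 3 the only one against that pattern. No measurement shown explains the loss with the benzyl group.

A benzylamino group without the methyl would show whether the aromatic ring or the substitution on the nitrogen matters. A pyridin-3-ylmethyl group would test a second aromatic ring at this place.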